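The source may report more compounds than this note shows. Statements on the series, on what has been measured and on what is new or still open speak of the compounds shown alone.

Three compounds share one core and differ only in the substituted phenyl held on a nitrogen. In a functional assay on A-431 cells (Homo sapiens) for antiproliferative activity, read by MTT assay, with a stated time of 72 h (a lower number here means a stronger inhibitor, a higher number a weaker inhibitor), compound 1 `COc1cc2ncnc(Nc3cccc(Br)c3)c2cc1OCCCCC(=O)Nc1ccc(S(N)(=O)=O)cc1` gives 9750 nM, compound 3 `COc1cc2ncnc(Nc3ccc(Cl)cc3)c2cc1OCCCCC(=O)Nc1ccc(S(N)(=O)=O)cc1` gives 7120 nM, and compound 2 `COc1cc2ncnc(Nc3cccc(Cl)c3)c2cc1OCCCCC(=O)Nc1ccc(S(N)(=O)=O)cc1` gives the highest number of the three, 30400 nM. Compound 4 `COc1cc2ncnc(Nc3cccc(Cl)c3F)c2cc1OCCCCC(=O)Nc1ccc(S(N)(=O)=O)cc1` has not yet been measured; compared with compound 2 the change is fluoro in place of hydrogen on an aromatic carbon. Among the measured compounds shown here, no measured step adds a fluoro, so the closest guides are a 3.1-fold higher number from compound 1 to compound 2 (0.49 log units; beyond the scatter) and a 4.3-fold lower number from compound 2 to compound 3 (0.63 log units; beyond the scatter), both modest halogen changes on the same ring. A modest step toward a lower number is therefore expected, a 2.0-fold lower number from compound 2 to compound 4 (0.31 log units; beyond the scatter), with real uncertainty about its direction. Compound 4 is estimated at 15000 nM, within 5000 nM to 45000 nM.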

Compound 4, half-maximal inhibitory concentration: 5560 nM
For compound 4 the middle estimate is 2.7-fold (0.43 log units) above the measured one; measured number inside the range.
By their numbers in this assay, from the lowest: compounds 4, 3 and 1 (each within the scatter of the next); then compound 2.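

In this assay, among the compounds shown here, the fluoro, placed ortho to a chloro group, gives a 5.5-fold lower number from compound 2 to compound 4 (0.74 log units; beyond the scatter) and is the only step here that adds an atom rather than exchanging a halogen or its place. It also removes what set compound 2 apart, since the remaining comparisons read a 1.3-fold lower number from compound 3 to compound 4 (0.11 log units; within the scatter) and a 1.8-fold lower number from compound 1 to compound 4 (0.24 log units; within the scatter) and leave these three together. Nothing measured here explains the gain. Still open, on these data alone, is whether the fluoro acts alike on the rings of compound 1 and compound 3, and whether a methoxy or an amine in its place would match it.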